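The compounds below may be only part of what the source reports. "The series", "measured", "known", "first", "only" and "open" are said of these compounds alone.

Compound 1 `O=C(Nc1cccc(-n2cc(-c3ccncc3)c(-c3ccc(Cl)c(O)c3)n2)c1)Nc1ccc(Cl)c(Cl)c1` and compound 2 `COc1cc(-c2nn(-c3cccc(NC(=O)c4cccc(C(F)(F)F)c4)c3)cc2-c2ccncc2)ccc1Cl` share a core carrying a pyridine-bearing pyrazole. In a functional assay on PC-3 cells (Homo sapiens) for inhibition, read by sulforhodamine B assay, with a stated time of 48 h (on this read-out higher numbers stand for weaker inhibition of growth and lower numbers for stronger inhibition of growth), compound 1 gives 834 nM, the lower of the two numbers recorded, while compound 2 gives 1230 nM, a gap that lies within the usual scatter, so the two cannot be ordered. Compound 3 `O=C(Nc1cccc(-n2cc(-c3ccncc3)c(-c3ccc(Cl)c(O)c3)n2)c1)Nc1ccc(Cl)c(C(F)(F)F)c1` is derived from compound 1 by trifluoromethyl in place of chloro on an aromatic carbon. Within the data shown here, no measured pair shows this change, so its size is unknown; the expected step from compound 1 to compound 3 is a 1.2-fold lower number from compound 1 to compound 3 (0.08 log units; within the scatter), none beyond the scatter. Compound 3 is estimated at 700 nM, within 250 nM to 2000 nM.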

Compound 3, concentration for 50% growth inhibition: 5880 nM
The estimate for compound 3 lay 8.4-fold (0.92 log units) below the measured number, outside the stated range (above it).
By their numbers in this assay, from the lowest: compounds 1 and 2 (each within the scatter of the next); then compound 3.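

Trifluoromethyl in place of chloro, ortho to a chloro group, gives a 7.1-fold higher number from compound 1 to compound 3 (0.85 log units; beyond the scatter) in this assay, so growth inhibition weakens beyond the scatter. This shows that the read-out responds to a change at this position on the 3,4-dichlorophenyl group, even though the entering group adds no hydrogen-bond donors or acceptors and no net charge. Nothing measured here accounts for the loss. From the compounds shown here alone, whether fluoro, methyl or methoxy at this position would keep the number close to that of compound 1 remains open.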